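The compounds below may be only part of what the source reports. "The series", "measured", "known", "first", "only" and "open" are said of these compounds alone.

Series values in a functional assay, read by spectrophotometry, with a stated time of 30 min; a lower number here means a stronger inhibitor, a higher number a weaker inhibitor:
- compound 1 `CC(C)(C)c1cc(/C=C/C(=O)NCCC2CCN(Cc3ccccc3)CC2)cc(C(C)(C)C)c1O`: 81700 nM
- compound 2 `CC(C)(C)c1cc(/C=C/C(=O)NCCC2CCN(Cc3ccccc3Cl)CC2)cc(C(C)(C)C)c1O`: 80200 nM

Compound 2 gives 80200 nM, and compound 1 gives 81700 nM. These two values lie within the scatter of each other, so they cannot be placed in any order.

The next compound to be read is compound 3 `CC(C)(C)c1cc(/C=C/C(=O)NCCC2CCN(Cc3ccc(C#N)cc3)CC2)cc(C(C)(C)C)c1O`. The change is 4-cyanophenyl in place of 2-chlorophenyl on a saturated chain carbon bound to an amine nitrogen in a ring. In words, 4-cyanophenyl stands in place of 2-chlorophenyl on a saturated chain carbon bound to an amine nitrogen in a ring, or 2-chlorobenzyl is replaced by 4-cyanobenzyl.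

Among the compounds with values here, only one measured step bears on this change: a 1.0-fold lower number from compound 1 to compound 2 (0.01 log units; within the scatter). That step puts chloro in place of hydrogen on an aromatic carbon of the same benzyl group, and it stays within the scatter. Within the data shown here, no measured compound carries a nitrile, so this evidence is indirect. No shift beyond the scatter is therefore expected in this assay, and no direction is favoured with any confidence.

The expected step is a 1.1-fold lower number from compound 2 to compound 3 (0.03 log units; within the scatter). For compound 3 the estimated value is 75000 nM, with an expected range of 30000 nM to 160000 nM.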

Compound 3, half-maximal inhibitory concentration: 79500 nM
Compound 3: middle estimate off by 1.1-fold (0.03 log units), on the low side; low and high end bracket the measured number.
By their numbers in this assay, from the lowest: compounds 3, 2 and 1 (each within the scatter of the next).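

In this assay, 4-cyanobenzyl in place of 2-chlorobenzyl gives a 1.0-fold lower number from compound 2 to compound 3 (0.00 log units; within the scatter), and the nitrile in place of hydrogen on the aromatic carbon gives a 1.0-fold lower number from compound 1 to compound 3 (0.01 log units; within the scatter). The benzyl group on the ring amine nitrogen now extends beyond a single chloro example: the unsubstituted, 2-chloro and 4-cyano forms cannot be separated from one another, even though the two substituted forms differ in both the group and its printed position on the aromatic ring. No measurement is available to explain this lack of separation.

The compounds shown leave open whether this reading would hold for a carboxylic acid or an amine on the aromatic ring, or for a longer chain in place of the benzyl group. They also leave open whether a change in the shared core, away from the benzyl group, would give a number that can be separated from these three.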